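Swapping bromo for fluoro in compound 4

The source may hold more compounds than are shown below. What is called first, only, known or untested is meant among the compounds shown, and "the series" means these compounds.

Measured so far in a functional assay on PC-3 cells (Homo sapiens) for cytotoxicity, read by colorimetric assay; a higher number here means a weaker inhibitor, a lower number a stronger inhibitor
- compound 1 `O=C(NO)c1ccc(CN2C(=O)/C(=C3\Nc4ccccc4\C3=N/O)c3cc(F)ccc32)cc1` gives 50 nM
- compound 2 `COc1ccc2c(c1)/C(=C1/Nc3ccccc3/C1=N\O)C(=O)N2Cc1ccc(/C=C/C(=O)NO)cc1` gives 30 nM
- compound 3 `O=C(/C=C/c1ccc(CN2C(=O)/C(=C3\Nc4ccccc4\C3=N/O)c3cc(Br)ccc32)cc1)NO` gives 90 nM

Compound 3 lies within the scatter of compound 1 and clearly apart from compound 2. Compound 4 `O=C(/C=C/c1ccc(CN2C(=O)/C(=C3\Nc4ccccc4\C3=N/O)c3cc(F)ccc32)cc1)NO` differs from compound 3 in one place (fluoro in place of bromo on an aromatic carbon): fluoro in place of bromo on an aromatic carbon. Going by the values given here, no measured step makes this exact swap. The nearest is a 3.0-fold higher number from compound 2 to compound 3 (0.48 log units; beyond the scatter), a modest step with bromo in place of methoxy. Compound 1 also carries fluoro, on a different chain, and gives 50 nM, so a small move to a lower number seems likely. The expected change is a 1.8-fold lower number from compound 3 to compound 4 (0.26 log units; within the scatter), probably within the scatter. Compound 4 is estimated at 50 nM, with an expected range from 20 nM to 120 nM.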

Compound 4, half-maximal inhibitory concentration: 50 nM
The estimate for compound 4 equals the measured number at the digits printed; measured number inside the range.
By their numbers in this assay, from the lowest: compounds 2, 1, 4 and 3 (each within the scatter of the next, the first and the last beyond it).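

In this assay, fluoro in place of bromo on this aromatic carbon gives a 1.8-fold lower number from compound 3 to compound 4 (0.26 log units; within the scatter), so these two halogens are not told apart here. Methoxy stood clearly apart from bromo, yet fluoro in place of methoxy gives a 1.7-fold higher number from compound 2 to compound 4 (0.22 log units; within the scatter), which also does not separate them. Elsewhere in the molecule, 2-(hydroxycarbamoyl)ethenyl in place of hydroxycarbamoyl gives no change at the digits printed from compound 1 to compound 4 (within the scatter), the first direct comparison of these two chains.

No available data explain these results. From the compounds shown here alone, it remains open whether an amine or a carboxylic acid on this aromatic carbon would stand beyond the scatter.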